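Tolerability notes: from compound 1 toward compound 4

The source may report more compounds than this note shows. Statements on the series, on what has been measured and on what is new or still open speak of the compounds shown alone.

Compound 1 `CC(C)Nc1nc(N)nc2c1ncn2/C=C1/CC1(CO)CO`: "not determined" (no result reported)
Compound 2 `CCCCCOc1nc(N)nc2c1ncn2/C=C1/CC1(CO)CO`: > 20000 nM
Compound 3 `CC(C)Sc1nc(N)nc2c1ncn2/C=C1/CC1(CO)CO`: > 20000 nM

In an ADME assay on MOLT-3 cells (Homo sapiens) for cytotoxicity, with a stated time of 7 days (a higher number here means that more compound is tolerated, a lower number that less compound is tolerated), compound 1 gives "not determined" (no result reported), so it has no number of its own here. Compound 2 reaches only a limit of this assay, > 20000 nM. Compound 3 likewise reaches only a limit, > 20000 nM. The step that the two limits leave unreadable from compound 2 to compound 3 is therefore not readable in size or direction. What the series does show is the limit of > 20000 nM in this assay, at which 2 of the 3 values shown sit.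

Compound 4 `CCCCSc1nc(N)nc2c1ncn2/C=C1/CC1(CO)CO` is still to be measured. It differs from compound 1 by butylsulfanyl in place of isopropylamino on an aromatic carbon. For the measured compounds named here, no measured step covers this exact change; the only pair with both values, compound 2 and compound 3, sits at the limit on both sides and gives no size to carry over. With two of three values at the limit, the expectation for compound 4 is that this assay again reports a limit rather than a number, and any real value is expected to lie near or beyond it.

The estimate for compound 4 in this assay is 30000 nM, with a range from 8000 nM to 100000 nM.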

Compound 4, half-maximal cytotoxic concentration: > 20000 nM
Compound 4 was reported as a limit (the forecaster's own chance of this, stated with the estimate: 75%); the middle value is on the limit's open side.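

In this assay compound 4 reaches only the limit > 20000 nM and its steps from compound 2 and compound 3, also limits, cannot be read. The compounds shown leave open at what concentration compound 2, compound 3 or compound 4 would become cytotoxic, and whether they differ.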